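Removing the Hydroxymethyl Pyrrolidine: A Shrinking Amine Substituent

The source may hold more compounds than are shown below. What is called first, only, known or untested is meant among the compounds shown, and "the series" means these compounds.

Three compounds share one core and differ at two positions. Compound 1 `Clc1ccc(Nc2nc3c(N4CCCC4)ncnc3s2)cc1` carries a plain pyrrolidine; in an assay on CHO cells for displacement of a labelled ligand from adenosine receptor A1 (Homo sapiens), read by scintillation counting, with a stated time of 3 h (a lower number here means a stronger inhibitor, a higher number a weaker inhibitor), compound 1 gives only a limit, > 100000 nM, meaning no number could be determined. Compound 2 `OC[C@@H]1CCCN1c1ncnc2sc(Nc3ccc(Cl)cc3)nc12` adds a hydroxymethyl to that ring, and in this assay compound 2 gives 629 nM, which is an at least 150-fold lower number from compound 1 to compound 2 (2.20 log units; beyond the scatter). Compound 3 `OC[C@@H]1CCCN1c1ncnc2sc(Nc3cccc(Br)c3)nc12` moves the halogen on the aniline, and in this assay compound 3 gives 530 nM, a change of a 1.2-fold lower number from compound 2 to compound 3 (0.07 log units; within the scatter). Among the two actual numbers, compound 2 has the higher one, with compound 3 within the scatter of it.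

Compound 4 `CN(C)c1ncnc2sc(Nc3ccc(Cl)cc3)nc12` introduces (dimethylamino in place of 2-(hydroxymethyl)pyrrolidin-1-yl on an aromatic carbon). For the measured compounds named here, the one measured step bearing on this is the gain of the hydroxymethyl, an at least 150-fold lower number from compound 1 to compound 2 (2.20 log units; beyond the scatter), and compound 4 gives that hydroxymethyl up along with the ring, so a large step upward is expected, quite possibly back to a limit like (the limit of > 100000 nM in this assay, at which 1 of the 3 values shown sits). Compound 4 is therefore estimated at 50000 nM, with a range from 5000 nM to 300000 nM. The expected step is a 79-fold higher number from compound 2 to compound 4 (1.90 log units; beyond the scatter).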

Compound 4, inhibition constant: > 100000 nM
Compound 4 was reported as a limit; the forecaster's own chance of this, stated with the estimate: 50%; middle value at least 2.0-fold (0.30 log units) away from the limit.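

Replacing 2-(hydroxymethyl)pyrrolidin-1-yl with dimethylamino gives (an at least 150-fold higher number from compound 2 to compound 4 (2.20 log units; beyond the scatter)), so a second amine without the hydroxymethyl also lacks the measurable number seen for compound 2. Among the compounds shown, measurable numbers occur only with 2-(hydroxymethyl)pyrrolidin-1-yl, in compound 2 and compound 3, and the step between compound 1 and compound 4 cannot be read. Compound 4 is reported only as a limit, the same limit as compound 1: the limit of > 100000 nM in this assay, at which 2 of the 4 values shown sit.

The change to compound 4 removes the ring and the hydroxymethyl together, so it does not separate their contributions, and compound 1 has the ring but no hydroxymethyl. The compounds shown leave open whether a hydroxyl on an open chain, such as a 2-hydroxyethyl group on the amine nitrogen, would restore a measurable number without the ring.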